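Vero Cell Cytotoxicity Notes: Methyl to Bromo Step

The source may hold more compounds than are shown below. What is called first, only, known or untested is meant among the compounds shown, and "the series" means these compounds.

Measured compounds in an ADME assay on Vero cells (Chlorocebus sabaeus) for cytotoxicity, read by MTT assay, with a stated time of 72 h; a higher number here means a weaker inhibitor, a lower number a stronger inhibitor:
- Compound 1 `COc1nc(C)nc(/N=C/c2ccc(C)cc2)n1`: compound 1 gives > 50 ug/mL, a limit of the assay.
- Compound 2 `COc1nc(C)nc(/N=C/c2cc(OC)c(OC)c(OC)c2)n1`: compound 2 gives > 50 ug/mL, a limit of the assay.
- Compound 3 `CCOc1cc(/C=N/c2nc(C)nc(OC)n2)ccc1O`: compound 3 gives > 50 ug/mL, a limit of the assay.

Compound 1 stands where every measured member of the series stands: at the limit, with no number behind it. The same holds across the set, since (the limit of > 50 ug/mL in this assay, at which 3 of the 3 values shown sit). Among the measured compounds shown here, no pair of measured compounds differs in a single place, so no measured step exists and no size of effect for any change has been observed here.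

Compound 4 `COc1nc(C)nc(/N=C/c2ccc(Br)cc2)n1` is the next member and is not yet measured in this assay. It differs from compound 1 by bromo in place of methyl on an aromatic carbon. With three of three measured values sitting at the limit and nothing in the data pointing either way for this change, the expectation is no step beyond the scatter, and most likely another limit rather than a number. Compound 4 is therefore estimated at 60 ug/mL, within 30 ug/mL to 200 ug/mL. The expected step is a step that the limit leaves unreadable from compound 1 to compound 4, which is expected to remain within the scatter.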

Compound 4, half-maximal inhibitory concentration: > 50 ug/mL
Compound 4 gave a limit, no number; the forecaster's own chance of this, stated with the estimate: 80%; the middle value is on the limit's open side.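

Compound 1 and compound 4 both give only a limit in this assay, so no step can be read for bromo in place of methyl. The compounds shown leave open what size of value any member of this series would give, since none yet gives a number: the limit of > 50 ug/mL in this assay, at which 4 of the 4 values shown sit.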